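This account rests on a few compounds, and the source may have more. Where it says the series, first, only, none or still open, it means among the compounds named here.

Measured compounds in a functional assay on Malme-3M cells (Homo sapiens) for cytotoxicity, read by sulforhodamine B assay, with a stated time of 48 h, tested at 100 uM; on this read-out lower numbers stand for a stronger effect and higher numbers for a weaker effect at the one concentration tested:

Compound 1, `COc1cc(-c2cc(/C=C/C(=O)c3ccc(N)cc3)[nH]n2)cc(OC)c1OC`, gives -76%.
Compound 2, `COc1cc(-c2cc(/C=C/C(=O)c3ccc(Cl)c(Cl)c3)[nH]n2)cc(OC)c1OC`, gives 24%.
Compound 3, `COc1ccc(C(=O)/C=C/c2cc(-c3cc(OC)c(OC)c(OC)c3)n[nH]2)cc1OC`, gives -81%.

Compound 3 has the lowest of the three numbers. Its nearest neighbour is compound 1, which sits a number 5 percentage points lower from compound 1 to compound 3 (within the scatter), so the two cannot be told apart. Compound 2 stands far off: the change from the 3,4-dichlorophenyl to the 3,4-dimethoxyphenyl on the carbonyl carbon gave a number 105 percentage points lower from compound 2 to compound 3 (beyond the scatter), and the related step of a number 100 percentage points higher from compound 1 to compound 2 (beyond the scatter) was of the same size in the opposite direction.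

Compound 4, `COc1cc(C(=O)/C=C/c2cc(-c3cc(OC)c(OC)c(OC)c3)n[nH]2)cc(OC)c1OC`, differs from compound 3 in one place: methoxy in place of hydrogen on an aromatic carbon. The measured steps concern the exchange of one aryl group for another on the carbonyl carbon; none of them adds a single methoxy to an already substituted ring, so they bear only loosely on this change. What they do show is that compound 3 and compound 1, both carrying oxygen- or nitrogen-bearing aryl groups, sit close together, while only the dichloro analogue compound 2 falls away. The account therefore expects a small step, if any, in this assay .

Compound 4 is accordingly estimated to give -78%, within a range from -95% to -50%, which means an expected step of a number 3 percentage points higher from compound 3 to compound 4 (within the scatter), not beyond the scatter.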

Compound 4, a percentage reported as activity, at one concentration (the size of the read-out at that concentration, not a potency): -94%
Compound 4: the middle estimate sits 16 percentage points above what was measured; low and high end bracket the measured number.
By their numbers in this assay, from the lowest: compound 4; then compounds 3 and 1 (each within the scatter of the next); then compound 2.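

In this assay, methoxy in place of hydrogen, on an aromatic carbon ortho to a methoxy group and meta to a second methoxy group and to a large group, gives a number 13 percentage points lower from compound 3 to compound 4 (beyond the scatter), a modest step in the direction of a stronger effect at the one concentration tested. Among these compounds, the earlier steps each exchanged one whole aryl group on the carbonyl carbon for another, so this is the first sign that a single added group on an already substituted ring can move the number beyond the usual scatter, and that this position still responds when compound 3 already reads low. No measurement at hand bears on why the added methoxy has this effect.

The compounds shown leave open whether the step belongs to methoxy itself or would also appear with a hydroxyl, an ethoxy or an amine on the same aromatic carbon. They also leave open whether the step would carry over to other concentrations, as the read-out here is the size of the effect at one concentration only.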